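A few compounds are considered here, and "the series" means these few. Any claim that something is new, unique, unknown or untested is made for them only; others in the source may bear on it.

Measured so far:
Compound 1 `O=C1NC2(CC2c2ccc3cccc(OCc4ccccc4)c3n2)C(=O)N1C1CCCCC1` gives 300 mg/kg in a functional assay on the whole organism (strain Kunming) with Mus musculus as the target, in the maximal electroshock model, with a stated time of 4 h; on this read-out higher numbers stand for an effect only at larger amounts of compound and lower numbers for an effect already at smaller amounts.
Compound 2 `O=C1NC2(CC2c2ccc3cccc(OCc4ccccc4)c3n2)C(=O)N1Cc1ccccc1` gives 300 mg/kg in this assay.

Compound 2 stands level with compound 1 on the numbers shown, and the only measured step, no change at the digits printed from compound 1 to compound 2 (within the scatter), was within the scatter. The compound not yet measured is compound 3 `O=C1NC2(CC2c2ccc3cccc(OCc4ccccc4)c3n2)C(=O)N1c1ccc(C(F)(F)F)cc1`, which differs from compound 2 in one place: 4-(trifluoromethyl)phenyl in place of benzyl on an amide-type nitrogen in a ring. Going by the values given here, the one step that bears on this change is the exchange on the same ring nitrogen, no change at the digits printed from compound 1 to compound 2 (within the scatter), which altered nothing beyond the scatter; a ring group or a saturated ring at this position gave the same minimum effective dose. On that basis compound 3 is expected to show no step beyond the scatter, no change at the digits printed from compound 2 to compound 3 (within the scatter), when the group on this nitrogen is again exchanged. Compound 3 is therefore estimated at 300 mg/kg in this assay, within a range from 100 mg/kg to 600 mg/kg. Among the compounds with values here, only two compounds support this expectation, so it is held loosely.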

Compound 3, minimum effective dose: 300 mg/kg
Beside the measured number, compound 3's estimate shows no gap at the digits printed; measured number inside the range.
By their numbers in this assay, from the lowest: compounds 1, 2 and 3 (each within the scatter of the next).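

The exchange of benzyl for 4-(trifluoromethyl)phenyl in this assay brings three fluorine atoms to this ring nitrogen, and the step reads no change at the digits printed from compound 2 to compound 3 (within the scatter) in this series. Set against the saturated group, the same entering group gives no change at the digits printed from compound 1 to compound 3 (within the scatter), so cyclohexyl, benzyl and 4-(trifluoromethyl)phenyl now stand level at this position, where the earlier compounds offered only one exchange and no fluorine-bearing group. No measurement shown here bears on why these exchanges leave the minimum effective dose in place.

As far as these compounds go, whether an amine, a carboxylic acid or a longer alkyl chain on this nitrogen would give a different minimum effective dose remains open. The compounds shown also leave open whether changes elsewhere on the shared core would move the read-out.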